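Capping the Hydroxyl of a Trifluoromethylphenyl Urea

The source may hold more compounds than are shown below. What is called first, only, known or untested is meant among the compounds shown, and "the series" means these compounds.

Compound 1, `O=C(Nc1cccc(C(F)(F)F)c1)N[C@H]1CC[C@H](O)CC1`, is a urea joined on one side to an aromatic ring bearing a trifluoromethyl group and on the other to a saturated ring carrying a hydroxyl. In a functional assay on CRL2813 cells (Homo sapiens) for cytotoxicity, read by sulforhodamine B assay, with a stated time of 5 days (on this read-out lower numbers stand for stronger inhibition and higher numbers for weaker inhibition), compound 1 gives > 20000 nM, which is a limit of the assay rather than a number. Compound 2, `COc1ccc(NC(=O)N[C@H]2CC[C@H](Oc3ccc(F)cc3)CC2)cc1`, pairs a methoxyphenyl urea with a fluorinated phenoxy group on the saturated ring. In this assay compound 2 gives > 20000 nM, again a limit. Where compound 1 stands is set by the limit of > 20000 nM in this assay, at which 2 of the 2 values shown sit, so no comparison of size is possible. Compound 3, `O=C(Nc1cccc(C(F)(F)F)c1)N[C@H]1CC[C@H](Oc2ccccc2F)CC1`, arises from compound 1 by 2-fluorophenyl in place of hydrogen on an oxygen on a saturated carbon. Within the data shown here, no measured step exists here, and no direction of change beyond the scatter can be anticipated. The estimated step of a number no higher from compound 1 to compound 3 (the limit leaves the size open) is expected to be small. Compound 3 is expected to give about 20000 nM, within 6000 nM to 60000 nM, most likely once more as a limit.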

Compound 3, half-maximal inhibitory concentration: 2450 nM
Compound 3: the middle estimate sits 8.2-fold (0.91 log units) above what was measured; measured number outside the range, below it.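

In this assay, putting 2-fluorophenyl in place of the hydrogen on the oxygen on a saturated carbon gives an at least 8.1-fold lower number from compound 1 to compound 3 (0.91 log units; beyond the scatter). This oxygen is therefore a place in the core where a single change moves the read-out from a limit of the assay to a real number, something neither earlier compound could show. Only a minimum can be given for this step, because one of its two ends is a limit: the limit of > 20000 nM in this assay, at which 2 of the 3 values shown sit.

The compounds shown do not tell whether the aromatic ring or its fluorine accounts for the step, and a plain phenyl, a benzyl or a methyl group on the same oxygen would help to separate the two. As far as these compounds go, whether an amine in place of this oxygen would keep the effect also stays open.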